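Swapping Thiophene for Phenyl in an Antiproliferative Series

This account rests on a few compounds, and the source may have more. Where it says the series, first, only, none or still open, it means among the compounds named here.

Of the compounds shown here, two have been measured so far. In a functional assay on SK-MEL-2 cells (Homo sapiens) for antiproliferative activity (a higher number here means a weaker inhibitor of growth, a lower number a stronger inhibitor of growth), compound 1 (`c1ccc(-c2cc(-c3cccnc3)nc(-c3ccccn3)c2)cc1`) gives 89.2 ug/mL, while compound 2 (`c1ccc(-c2cc(-c3ccsc3)cc(-c3ccccn3)n2)nc1`) gives 0.89 ug/mL. Compound 2 therefore holds the lower number of the pair and is the stronger growth inhibitor, with a gap well beyond the usual scatter of repeated measurements.

The next compound to be tested is compound 3 (`c1ccc(-c2cc(-c3ccccn3)nc(-c3ccccn3)c2)cc1`). It carries phenyl in place of thiophen-3-yl on an aromatic carbon, opposite the ring nitrogen (phenyl in place of thiophen-3-yl on an aromatic carbon). The rest of compound 2 stays the same.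

Within the data shown here, no two measured compounds differ in just one place, so the data do not directly show what a swap like this does. Both groups are aromatic rings, so the expectation starts from compound 2 at 0.89 ug/mL and is for little change in this assay. The expected shift is a 1.3-fold higher number from compound 2 to compound 3 (0.13 log units; within the scatter), which would not go beyond the scatter. For compound 3, the estimated value is 1.2 ug/mL, with an expected range of 0.3 ug/mL to 5 ug/mL.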

Compound 3, concentration for 50% growth inhibition: 7.5 ug/mL
Compound 3: middle estimate off by 6.3-fold (0.80 log units), on the low side, and the stated range ends below it.
By their numbers in this assay, from the lowest: compound 2; then compound 3; then compound 1.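

In this assay, the group opposite the ring nitrogen clearly matters: phenyl in place of thiophen-3-yl gives an 8.4-fold higher number from compound 2 to compound 3 (0.93 log units; beyond the scatter), so at this position these two aromatic rings cannot be treated as interchangeable, even though both are flat rings without a charge. The other step shows that a smaller-looking change elsewhere on the shared core also counts, since pyridin-2-yl in place of pyridin-3-yl on an aromatic carbon gives a 12-fold lower number from compound 1 to compound 3 (1.08 log units; beyond the scatter), and so the placing of the nitrogen within that ring affects growth inhibition in these cells. Nothing available explains either step.

Going by these compounds, it remains open whether other groups opposite the ring nitrogen, such as furan-3-yl, a small amine or a short alkyl chain, would match thiophen-3-yl, fall nearer to phenyl or behave differently from both. On these data alone, it is also open whether the two changes act independently, that is, whether thiophen-3-yl would still give the lower number with pyridin-3-yl in place of pyridin-2-yl.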